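The source may report more compounds than this note shows. Statements on the series, on what has been measured and on what is new or still open speak of the compounds shown alone.

Compound 1 `Oc1ccc(-c2cc(-c3cccs3)cc(-c3ccccc3O)n2)cc1` gives > 50000 nM in a functional assay on T47D cells (Homo sapiens) for cytotoxicity, read by CCK-8 assay; on this read-out lower numbers stand for stronger inhibition and higher numbers for weaker inhibition; this is a limit of the assay, not a number.
Compound 2 `Oc1ccccc1-c1cc(-c2ccco2)cc(-c2ccccc2O)n1` gives > 50000 nM in this assay; this too is a limit of the assay, not a number.

Going by the values given here, compound 2 stands where the only other measured compound stands as well: both results are limits, as the limit of > 50000 nM in this assay, at which 2 of the 2 values shown sit, records. Among the compounds with values here, no measured step joins compound 1 and compound 2 that differs in a single place, so the two values show only that neither compound reached a measurable inhibition of these cells within the tested range.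

Compound 3 `Oc1ccc(-c2cc(-c3ccco3)cc(-c3ccccc3O)n2)cc1` has not yet been measured. It differs from compound 2 in one place: 4-hydroxyphenyl in place of 2-hydroxyphenyl on an aromatic carbon. The two have the same atoms, joined differently. Within the data shown here, with no measured step to lean on, and both known values sitting at the limit, there is no basis for expecting a shift in this assay beyond the scatter; the most likely outcome is that compound 3 also returns a limit. Compound 3 is expected to give about 50000 nM in this assay, with a range from 15000 nM to 200000 nM. The step this estimate means, a number no higher from compound 2 to compound 3 (the limit leaves the size open), is expected to be none beyond the scatter.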

Compound 3, half-maximal inhibitory concentration: > 50000 nM
Compound 3: a limit, no number (the forecaster's own chance of this, stated with the estimate: 80%); the middle value lies on the limit itself.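

No step can be read from compound 2 to compound 3 or from compound 1 to compound 3, because all three results are the same limit, not numbers: the limit of > 50000 nM in this assay, at which 3 of the 3 values shown sit.

The compounds shown leave open whether 4-hydroxyphenyl in place of 2-hydroxyphenyl, or furan-2-yl in place of thiophen-2-yl, changes the true value in this assay at all.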